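Moving one chlorine on the aryl group of compound 2

The source may report more compounds than this note shows. Statements on the series, on what has been measured and on what is new or still open speak of the compounds shown alone.

Going by the values given here, compound 2 `CN1CCN(c2nc(-c3cc(Cl)ccc3Cl)nc3[nH]cnc23)CC1` is the weaker of the two compounds measured so far in an assay on cells for displacement of a labelled ligand from adenosine receptor A1 (Homo sapiens), read by scintillation counting and radioligand binding, with a stated time of 60 min; on this read-out higher numbers stand for weaker inhibition and lower numbers for stronger inhibition. Compound 2 gives 2510 nM, whereas compound 1 `CN1CCN(c2nc(-c3cccc(Cl)c3)nc3[nH]cnc23)CC1` gives 79.4 nM; the step of a 32-fold higher number from compound 1 to compound 2 (1.50 log units; beyond the scatter) came with chloro in place of hydrogen on an aromatic carbon. Compound 3 `CN1CCN(c2nc(-c3ccc(Cl)cc3)nc3[nH]cnc23)CC1` has not yet been measured. It differs from compound 2 by 4-chlorophenyl in place of 2,5-dichlorophenyl on an aromatic carbon. Among the compounds with values here, the only step available shows that adding a second chlorine to the aryl group of compound 1 weakened binding greatly; compound 3 removes that extra chlorine and shifts the remaining one, so a large return toward the number of compound 1 is expected. The estimate for compound 3 is 150 nM with a range from 40 nM to 600 nM. This means an expected step of a 17-fold lower number from compound 2 to compound 3 (1.22 log units; beyond the scatter), with the uncertainty of a new substitution pattern kept in mind.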

Compound 3, inhibition constant: 398 nM
Compound 3: the middle estimate sits 2.7-fold (0.42 log units) below what was measured; the range from low to high includes it.
By their numbers in this assay, from the lowest: compound 1; then compound 3; then compound 2.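

In this assay, the change to 4-chlorophenyl gives a 6.3-fold lower number from compound 2 to compound 3 (0.80 log units; beyond the scatter), so replacing the 2,5-dichlorophenyl group recovers part of the binding strength seen with compound 1, but not all of it. Both compounds in the next comparison carry a single chlorine on the phenyl ring, and going from 3-chlorophenyl to 4-chlorophenyl still gives a 5.0-fold higher number from compound 1 to compound 3 (0.70 log units; beyond the scatter), so where the chlorine sits matters as well as how many chlorines are present. Nothing available explains why either change shifts the number as it does.

On these data alone, it remains open how a phenyl group with no chlorine, or a 2-chlorophenyl group, would compare with these three compounds. Also open, as far as these compounds go, is whether a methoxy group or an amine in place of the chlorine would show the same dependence on ring location.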